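Swapping the benzyl substituent on a nucleoside scaffold

The compounds below may be only part of what the source reports. "The series", "measured", "known", "first", "only" and "open" are said of these compounds alone.

The three compounds already tested share one core, a sugar-linked purine-like scaffold carrying a benzyl amine, and differ only in the ring at the end of that benzyl group. Within the data shown here, compound 1, `OC[C@H]1O[C@@H](n2cnc3c(NCc4ccc(F)cc4)ncnc32)[C@H](O)[C@@H]1O`, is the only one to give a number: in a functional assay on HOS cells (Homo sapiens) for antiproliferative activity, with a stated time of 72 h (a lower number here means a stronger inhibitor, a higher number a weaker inhibitor), compound 1 gives 13200 nM. Compound 2, `OC[C@H]1O[C@@H](n2cnc3c(NCc4cccc(Br)c4)ncnc32)[C@H](O)[C@@H]1O`, reaches only a limit of the assay, > 166000 nM. Compound 3, `COc1ccc(CNc2ncnc3c2ncn3[C@@H]2O[C@H](CO)[C@@H](O)[C@H]2O)c(OC)c1`, likewise stops at a limit, > 166000 nM. Both steps away from compound 1 are therefore large losses: an at least 12-fold higher number from compound 1 to compound 2 (1.09 log units; beyond the scatter), and an at least 12-fold higher number from compound 1 to compound 3 (1.09 log units; beyond the scatter). The comparison between the two limits, a step that the two limits leave unreadable from compound 2 to compound 3, cannot be read.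

The untested compound 4, `OC[C@H]1O[C@@H](n2cnc3c(NCc4cccc(O)c4O)ncnc32)[C@H](O)[C@@H]1O`, makes a change of the same kind at the same place: 2,3-dihydroxyphenyl in place of 4-fluorophenyl on a saturated chain carbon bound to a nitrogen on an aromatic ring. Two changes of the ring on that benzyl carbon have each been followed by a large rise, and it is therefore expected that compound 4 will also be much weaker than compound 1, with a step of a 9.1-fold higher number from compound 1 to compound 4 (0.96 log units; beyond the scatter). The estimate for compound 4 is 120000 nM, between 25000 nM and 400000 nM, with a fair chance that only a limit is reported, as it was for the other two ring variants.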

Compound 4, half-maximal inhibitory concentration: > 166000 nM
Compound 4 ended at the assay's limit; the forecaster's own chance of this, stated with the estimate: 55%; middle value at least 1.3-fold (0.14 log units) away from the limit.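

In this assay, the move to 2,3-dihydroxyphenyl gives an at least 12-fold higher number from compound 1 to compound 4 (1.09 log units; beyond the scatter), a size set by the limit that compound 4 reached rather than by a true number. The earlier losses came with bromine and with methoxy groups, whereas this one comes with a ring bearing two hydroxyl groups, which adds hydrogen-bond donors and acceptors where 4-fluorophenyl has neither, so the loss at this position now spans three different kinds of ring substituent and, among the four compounds shown, only the 4-fluorophenyl of compound 1 gives a number. Compound 2, compound 3 and compound 4 cannot be ordered among themselves, and the steps between them cannot be read: the limit of > 166000 nM in this assay, at which 3 of the 4 values shown sit.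

Going by these compounds, it remains open whether the fluorine matters at all, since a plain phenyl ring or a 4-chlorophenyl ring at the same place would test whether a number survives without it or with another halogen. A single hydroxyl, as in 4-hydroxyphenyl, would also show whether a hydroxyl group can be tolerated on this ring.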